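Aryl sulfone series: methoxy in place of cyclohexyl

A few compounds are considered here, and "the series" means these few. Any claim that something is new, unique, unknown or untested is made for them only; others in the source may bear on it.

compound 1, `Cc1cc(C)c(S(=O)(=O)c2cc(C)c(C)cc2C)c(C)c1`: 700 nM
compound 2, `Cc1cc(C)c(S(=O)(=O)c2ccc(C3CCCCC3)cc2)c(C)c1`: > 300000 nM

In an assay on isolated protein for antagonist activity at Rap guanine nucleotide exchange factor 4 (Homo sapiens), read by fluorescence and cAMP accumulation (on this read-out lower numbers stand for stronger inhibition and higher numbers for weaker inhibition), compound 1 gives 700 nM. For compound 2 the reading is a limit of the assay, not a number: > 300000 nM, which is the limit of > 300000 nM in this assay, at which 1 of the 2 values shown sits. Compound 3, `COc1ccc(S(=O)(=O)c2c(C)cc(C)cc2C)cc1`, differs from compound 2 by methoxy in place of cyclohexyl on an aromatic carbon. Going by the values given here, no measured pair isolates this change, so its size is open. Compound 1, with the same core, stays measurable at 700 nM. Some gain from compound 2 is therefore expected, though compound 3 is still expected to be weak. The step from compound 2 to compound 3 is estimated at an at least 6.0-fold lower number from compound 2 to compound 3 (0.77 log units; beyond the scatter). Compound 3 is expected near 50000 nM, within 5000 nM to 300000 nM.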

Compound 3, half-maximal inhibitory concentration: 1900 nM
Estimate against measurement, compound 3: 26-fold (1.42 log units) above, outside the stated range (below it).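

The change of cyclohexyl to methoxy on this aromatic carbon, para to a large group, gives an at least 150-fold lower number from compound 2 to compound 3 (2.19 log units; beyond the scatter) in this assay. A single substituent at this position thus separates a reading at the assay limit from a measured value. The reading for compound 2 is only a limit, so the full size of the step stays unknown: the limit of > 300000 nM in this assay, at which 1 of the 3 values shown sits.

On these data alone, whether the gain comes from losing cyclohexyl or from gaining methoxy stays open. Methyl, hydroxyl or an amine at this position would bear on that question.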